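Compound 1 without dimethylamino: working notes

The compounds below may be only part of what the source reports. "The series", "measured", "known", "first", "only" and "open" are said of these compounds alone.

Values in a functional assay on Gurav cells (Homo sapiens) for inhibition, read by sulforhodamine B assay; on this read-out lower numbers stand for stronger inhibition of growth and higher numbers for weaker inhibition of growth:
compound 1 `Cc1ccc2[nH]c(-c3ccc(-c4ccc(-c5ccc(N(C)C)cc5)cc4)cc3)nc2c1` gives 6240 nM
compound 2 `CN(C)c1ccc(-c2ccc(-c3ccc(-c4nc5ccccc5[nH]4)cc3)cc2)cc1` gives 100000 nM
compound 3 `CN(C)c1ccc(-c2ccc(-c3ccc(-c4nc5c(O)cccc5[nH]4)cc3)cc2)cc1` gives 8210 nM

Compound 1 stands at the low end of these three numbers, level within the scatter with its nearest neighbour: a 1.3-fold higher number from compound 1 to compound 3 (0.12 log units; within the scatter). The furthest value is a 16-fold higher number from compound 1 to compound 2 (1.20 log units; beyond the scatter).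

The next compound to be read in this assay is compound 4 `Cc1ccc2[nH]c(-c3ccc(-c4ccc(-c5ccccc5)cc4)cc3)nc2c1`. It has hydrogen in place of dimethylamino on an aromatic carbon, para to a large group: hydrogen in place of dimethylamino on an aromatic carbon. The same change reads as 4-(dimethylamino)phenyl to phenyl.

Among the measured compounds shown here, all three measured compounds carry dimethylamino, so no measured step removes it and none gives a direct guide to this change. The data bear on it only indirectly. Single small replacements elsewhere in the series gave large steps, a 16-fold higher number from compound 1 to compound 2 (1.20 log units; beyond the scatter) and a 12-fold lower number from compound 2 to compound 3 (1.09 log units; beyond the scatter), so a wide range is warranted. The direction is a weak expectation, resting on compound 1 having 6240 nM at the low end, with more room above it in the series than below.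

A moderate step is expected, estimated as a 2.4-fold higher number from compound 1 to compound 4 (0.38 log units; beyond the scatter). Compound 4 is expected at about 15000 nM, with an estimated range of 4000 nM to 60000 nM.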

Compound 4, concentration for 50% growth inhibition: 3310 nM
Compound 4: the middle estimate sits 4.5-fold (0.66 log units) above what was measured, outside the stated range (below it).
By their numbers in this assay, from the lowest: compounds 4, 1 and 3 (each within the scatter of the next, the first and the last beyond it); then compound 2.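

In this assay, hydrogen in place of dimethylamino on an aromatic carbon, para to a large group, gives a 1.9-fold lower number from compound 1 to compound 4 (0.28 log units; within the scatter) and so leaves compound 1 and compound 4 level on this read-out. The growth inhibition seen with compound 1 therefore does not depend on dimethylamino at this position, a contrast with the methyl group on the other end of the molecule, where hydrogen in place of methyl gives a 16-fold higher number from compound 1 to compound 2 (1.20 log units; beyond the scatter) and lies beyond the scatter. Nothing in the available evidence accounts for how little this change registers and the result stands as an observation only.

Open, going by these compounds, is whether the position stays this tolerant with other groups there, such as a methoxy group, a primary amine or a carboxylic acid, since only dimethylamino and hydrogen are compared so far. Also open, on these data alone, is whether the same change behaves alike in the context of compound 2 or compound 3, where the other end of the molecule differs, given that this single comparison rests on the methyl-bearing compounds.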